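A few compounds are considered here, and "the series" means these few. Any claim that something is new, unique, unknown or untested is made for them only; others in the source may bear on it.

In a functional assay on HCT-116 cells (Homo sapiens) for antiproliferative activity, read by MTT assay, with a stated time of 72 h (a lower number here means a stronger inhibitor, a higher number a weaker inhibitor), compound 1 `COc1ncc(-c2ccc3c(c2)N(c2ccc(C)cc2)C(=O)CO3)cc1NS(=O)(=O)c1ccc(F)cc1` gives 22700 nM. Compound 2 `COc1cccc(N2C(=O)COc3ccc(-c4cnc(Cl)c(NS(=O)(=O)c5ccc(F)cc5)c4)cc32)c1` gives > 40000 nM, which is a limit and not a number. Compound 3 `COc1cccc(N2C(=O)COc3ccc(-c4cnc(OC)c(NS(=O)(=O)c5ccc(F)cc5)c4)cc32)c1` gives > 40000 nM, also a limit and not a number. Compound 3 therefore has no measured value and stands at the limit of > 40000 nM in this assay, at which 2 of the 3 values shown sit.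

Compound 4 `COc1ncc(-c2ccc3c(c2)N(c2ccccc2)C(=O)CO3)cc1NS(=O)(=O)c1ccc(F)cc1` differs from compound 3 at one place, with hydrogen in place of methoxy on an aromatic carbon. The same difference reads 3-methoxyphenyl to phenyl.

For the measured compounds named here, two measured steps bear on this change. The nearer one is an at least 1.7-fold higher number from compound 1 to compound 3 (0.24 log units; that floor lies within the scatter), which concerns the group on the amide-type nitrogen in a ring. The other, a step that the two limits leave unreadable from compound 2 to compound 3, lies at a different place and gives no usable size. Neither step measures the loss of the methoxy group itself, so any expectation is loose. Compound 1, at 22700 nM, shows that a measurable value is possible with a different group on that nitrogen, so a small move toward a lower number is expected, or none beyond the scatter. The expected change is an at least 1.3-fold lower number from compound 3 to compound 4 (0.12 log units; that floor lies within the scatter). Compound 4 is estimated at 30000 nM, with an expected range from 12000 nM to 70000 nM.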

Compound 4, half-maximal inhibitory concentration: 18800 nM
Beside the measured number, compound 4's estimate is 1.6-fold (0.20 log units) above it, within the range that was stated.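

Compound 3 carries a limit and not a number, so the effect of losing its methoxy group can be stated only as a floor: the limit of > 40000 nM in this assay, at which 2 of the 4 values shown sit. Even so, hydrogen in place of methoxy on the phenyl ring of the 3-methoxyphenyl group gives an at least 2.1-fold lower number from compound 3 to compound 4 (0.32 log units; beyond the scatter) in this assay and is the first change at this position that clears the scatter, whereas the earlier step on this nitrogen, an at least 1.7-fold higher number from compound 1 to compound 3 (0.24 log units; that floor lies within the scatter), had a floor within it. With readable values on both sides, phenyl and 4-methylphenyl on that nitrogen cannot be told apart, as a 1.2-fold lower number from compound 1 to compound 4 (0.08 log units; within the scatter) shows, so among the compounds shown only the 3-methoxyphenyl group goes with a value at the limit when the methoxy on the other aromatic ring is kept.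

On these data alone, the step between the chloro and methoxy compounds cannot be read, so whether that group matters stays unknown while the 3-methoxyphenyl group is in place. As far as these compounds go, it also remains open whether a hydroxyl group, an amine or a longer chain such as ethoxy, placed where the methoxy stood, would behave like methoxy or like hydrogen.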